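Notes on the biphenyl amide series: compound 3 to compound 4

This account rests on a few compounds, and the source may have more. Where it says the series, first, only, none or still open, it means among the compounds named here.

Measured so far:
compound 1 `CC(C)(N)CN(C(=O)[C@@H]1C[C@H]1c1ccccc1)c1ccc(-c2ccccc2)cc1` gives 1.4 nM
compound 2 `CC[C@H](C)[C@H](N)CN(C(=O)[C@@H]1C[C@H]1c1csc(C)n1)c1ccc(-c2ccccc2)cc1` gives 1500 nM
compound 3 `CCCc1ccc(-c2ccc(N(C[C@@H](N)[C@@H](C)CC)C(=O)[C@@H]3C[C@H]3c3ccccc3)cc2)cc1` gives 61 nM

All three values come from a functional assay for agonist activity at G protein-coupled receptor 88 (Homo sapiens), read by HTRF and cAMP accumulation; a lower number here means that less compound is needed, a higher number that more compound is needed for the effect. Compound 3 holds the second highest of the three numbers: compound 2 sits above it, beyond the scatter, and compound 1 sits below it, also beyond the scatter. Compound 4 `CC[C@H](C)[C@H](N)CN(C(=O)[C@@H]1C[C@H]1c1ccccc1)c1ccc(-c2ccc(CN(C)C)cc2)cc1` is not yet measured. It differs from compound 3 in one place, (dimethylamino in place of ethyl on a saturated chain carbon bound to an aromatic carbon), so that 4-propylphenyl becomes 4-((dimethylamino)methyl)phenyl. Going by the values given here, no measured pair shows this change. The step from compound 3 to compound 4 is expected to be small, a 1.5-fold lower number from compound 3 to compound 4 (0.18 log units; within the scatter), likely within the scatter and with no clear direction. Compound 4 is therefore estimated at 40 nM, with a range from 8 nM to 200 nM.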

Compound 4, half-maximal effective concentration: 460 nM
Beside the measured number, compound 4's estimate is 12-fold (1.06 log units) below it; the whole stated range lies below it.
By their numbers in this assay, from the lowest: compound 1; then compound 3; then compound 4; then compound 2.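

Replacing 4-propylphenyl with 4-((dimethylamino)methyl)phenyl gives a 7.5-fold higher number from compound 3 to compound 4 (0.88 log units; beyond the scatter) in this assay, the first single-place step read in the series. This position is therefore not indifferent to the change: with dimethylamino in place of ethyl, more compound is needed for the effect. No measurement at hand accounts for the step.

Going by these compounds alone, whether the nitrogen itself or the whole dimethylamino group drives this remains open, since only one pair carries it. As far as these compounds go, how a carboxylic acid or a longer chain would read at the same place also remains open.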